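Diethylamino for Dimethylamino on Two Related Cores

The source may report more compounds than this note shows. Statements on the series, on what has been measured and on what is new or still open speak of the compounds shown alone.

Compound 1, `CN(C)CCCn1c(N)c(-c2nc3ccccc3[nH]2)c2nc(C#N)c(C#N)nc21`, gives 2390 nM in a functional assay on HL60/MX2 cells (Homo sapiens) for antiproliferative activity, read by MTT assay, with a stated time of 48 h; a higher number here means a weaker inhibitor, a lower number a stronger inhibitor.
Compound 2, `CCN(CC)CCCn1c(N)c(-c2nc3ccccc3[nH]2)c2nc(C#N)c(C#N)nc21`, gives 1820 nM in this assay.
Compound 3, `CN(C)CCCCn1c(N)c(-c2nc3ccccc3n2C)c2nc(C#N)c(C#N)nc21`, gives 2580 nM in this assay.

Compound 4, `CCN(CC)CCCCn1c(N)c(-c2nc3ccccc3n2C)c2nc(C#N)c(C#N)nc21`, has not been measured. It differs from compound 3 by diethylamino in place of dimethylamino on a saturated chain carbon, four bonds along the chain from an aromatic nitrogen. The same kind of change already occurred once: compound 2 differs from compound 1 by diethylamino in place of dimethylamino on a saturated chain carbon, three bonds along the chain from an aromatic nitrogen, and the step there was a 1.3-fold lower number from compound 1 to compound 2 (0.12 log units; within the scatter). The two places are not identical, three bonds along the chain in the first pair against four in the second, and the difference between the core of compound 1 and the core of compound 3 is not broken down here. Resting on that one step, compound 4 is expected to land within the scatter of compound 3, an estimated 1.2-fold lower number from compound 3 to compound 4 (0.09 log units; within the scatter), giving an estimate of 2100 nM, between 1000 nM and 4400 nM.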

Compound 4, half-maximal inhibitory concentration: 1730 nM
The estimate for compound 4 lay 1.2-fold (0.08 log units) above the measured number, and the stated range covers the measured number.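

Putting diethylamino in place of dimethylamino, four bonds along the chain from an aromatic nitrogen, gives a 1.5-fold lower number from compound 3 to compound 4 (0.17 log units; within the scatter) in this assay. Set beside the earlier step, the same change looks alike on the two cores: the same change on two cores in this assay, a 1.3-fold lower number (0.12 log units; within the scatter) from compound 1 to compound 2 and a 1.5-fold lower number (0.17 log units; within the scatter) from compound 3 to compound 4, 1.1-fold (0.06 log units) apart, within the scatter of two such steps. This shows that the change moved the number by no more than the usual scatter on either core, but it does not show that diethylamino gives a real gain, and two pairs cannot establish how the change behaves on other cores.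

From the compounds shown here alone, whether a dipropylamino group, a primary amine or a longer chain would move the number beyond the scatter remains open.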